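The source may hold more compounds than are shown below. What is called first, only, known or untested is meant among the compounds shown, and "the series" means these compounds.

For the measured compounds named here, in a functional assay on the whole organism (strain Sprague-Dawley) for inhibition, with Rattus norvegicus as the target, with a stated time of 10 min (on this read-out lower numbers stand for an effect already at smaller amounts and higher numbers for an effect only at larger amounts of compound), compound 2 `CCOC(=O)c1cnc(-c2ccccc2OCC2CC2)[nH]c1=O` stands lowest of the two numbers so far at 0.3 mg/kg against compound 1 `CCOC(=O)c1cnc(-c2ccccc2OC)[nH]c1=O` at 10 mg/kg on the same read-out. Still unmeasured is compound 3 `CCOC(=O)c1cnc(-c2ccccc2SC)[nH]c1=O` with methylsulfanyl in place of cyclopropylmethoxy on an aromatic carbon as its difference from compound 2, that is, methylsulfanyl in place of cyclopropylmethoxy on an aromatic carbon, ortho to a large group. Going by the values given here, one measured step bears on this: a 33-fold lower number from compound 1 to compound 2 (1.52 log units; beyond the scatter) is large and beyond the scatter, and it goes with cyclopropyl in place of hydrogen on a saturated chain carbon bound to an oxygen on an aromatic ring. Compound 3 carries no cyclopropyl either, so much of that step is expected to be lost, although no exchange of oxygen for sulfur has been measured. The expected change is a higher number beyond the scatter, estimated as a 10-fold higher number from compound 2 to compound 3 (1.00 log units; beyond the scatter) and somewhat smaller than the step just described. For compound 3 the estimated value is 3 mg/kg with an expected range from 0.6 mg/kg to 15 mg/kg in this series.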

Compound 3, dose for 50% inhibition: > 25 mg/kg
Compound 3: no number, only a limit; the forecaster's own chance of this, stated with the estimate: 5%; middle value at least 8.3-fold (0.92 log units) from the limit.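

In this assay compound 3 gives > 25 mg/kg, which is a limit of the assay and not a number: the limit of > 25 mg/kg in this assay, at which 1 of the 3 values shown sits. Methylsulfanyl in place of cyclopropylmethoxy on this aromatic carbon gives an at least 83-fold higher number from compound 2 to compound 3 (1.92 log units; beyond the scatter), so the large gain seen with the cyclopropylmethoxy group does not carry over to this small sulfur-linked group. Methylsulfanyl in place of methoxy gives an at least 2.5-fold higher number from compound 1 to compound 3 (0.39 log units; beyond the scatter), which shows for the first time in this series that exchanging the linking oxygen for sulfur alone shifts the read-out beyond the scatter, even without any cyclopropyl involved.

As far as these compounds go, how far compound 3 lies past its limit stays open, so the full size of both steps cannot be given. Also open, from the compounds shown here alone, is whether cyclopropylmethylsulfanyl, a longer chain on sulfur, or an amine on this aromatic carbon would restore the low numbers of compound 2.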